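Hydroxyphenyl in place of trimethoxyphenyl at the saturated ring carbon

The compounds below may be only part of what the source reports. "The series", "measured", "known", "first", "only" and "open" are said of these compounds alone.

Measured compounds:
compound 1, `COc1cc([C@@H]2[C@H](Oc3ccccc3)C(=O)N2c2cc(OC)c(OC)c(OC)c2)cc(OC)c1OC`, in a functional assay on MCF7 cells (Homo sapiens) for antiproliferative activity, read by MTT assay, with stated times of 24 h and 72 h; on this read-out lower numbers stand for stronger inhibition and higher numbers for weaker inhibition: 29000 nM
compound 2, `COc1ccc([C@@H]2[C@H](Oc3ccccc3)C(=O)N2c2cc(OC)c(OC)c(OC)c2)cc1OC`, in this assay: 26000 nM
compound 3, `COc1cc(N2C(=O)[C@@H](Oc3ccccc3)[C@H]2c2ccc(O)c(O)c2)cc(OC)c1OC`, in this assay: 4500 nM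

Compound 1 sits at the weak end of the three numbers. Compound 2 is not separated from it, a 1.1-fold lower number from compound 1 to compound 2 (0.05 log units; within the scatter), whereas compound 3 is, a 6.4-fold lower number from compound 1 to compound 3 (0.81 log units; beyond the scatter).

Compound 4, `COc1cc(N2C(=O)[C@@H](Oc3ccccc3)[C@H]2c2cccc(O)c2)cc(OC)c1OC`, differs from compound 1 by 3-hydroxyphenyl in place of 3,4,5-trimethoxyphenyl on a saturated ring carbon. Among the measured compounds shown here, two measured steps bear on this change, both trading methoxy-bearing aryl for hydroxyl-bearing aryl at the same position: a 6.4-fold lower number from compound 1 to compound 3 (0.81 log units; beyond the scatter) and a 5.8-fold lower number from compound 2 to compound 3 (0.76 log units; beyond the scatter), each modest and beyond the scatter. Compound 4 carries one hydroxyl rather than two, so a smaller step in the same direction is expected, a 3.2-fold lower number from compound 1 to compound 4 (0.51 log units; beyond the scatter).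

For compound 4 in this assay the estimate is 9000 nM, within 3500 nM to 25000 nM.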

Compound 4, half-maximal inhibitory concentration: 54000 nM
Compound 4: middle estimate off by 6.0-fold (0.78 log units), on the low side, and the stated range ends below it.
By their numbers in this assay, from the lowest: compound 3; then compounds 2, 1 and 4 (each within the scatter of the next, the first and the last beyond it).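

At this saturated ring carbon, a single hydroxyl does not reproduce the gain seen with compound 3: in this assay, 3-hydroxyphenyl is not separated from 3,4,5-trimethoxyphenyl (a 1.9-fold higher number from compound 1 to compound 4 (0.27 log units; within the scatter)) and sits just beyond the scatter on the weak side of 3,4-dimethoxyphenyl (a 2.1-fold higher number from compound 2 to compound 4 (0.32 log units; beyond the scatter)). The second hydroxyl of 3,4-dihydroxyphenyl marks the largest difference in the series (a 12-fold higher number from compound 3 to compound 4 (1.08 log units; beyond the scatter)). Nothing measured on these compounds explains that step.

As far as these compounds go, whether an amine or a carboxylic acid on the aryl group at this carbon could stand in for that second hydroxyl remains open, as does the effect of replacing the phenoxy group.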